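Fluoro substitution on the core of compound 1

This account rests on a few compounds, and the source may have more. Where it says the series, first, only, none or still open, it means among the compounds named here.

Working notes on the series. Compound 1 `Cc1cc(C)c(CN2CCc3ccc(O[C@@H]4CCOC4)c(Cl)c3C2=O)c(=O)[nH]1` is the reference for this step. In an assay on Sf9 cells for inhibition of histone-lysine N-methyltransferase EZH2 (Homo sapiens), read by scintillation counting, with a stated time of 60 min, in the presence of a further agent that is not named here (on this read-out higher numbers stand for weaker inhibition and lower numbers for stronger inhibition), compound 1 gives 28 nM. Going by the values given here, that is the only number among the two values shown; the other value is a limit. Compound 2 `COc1cccc(C(=O)NCc2c(C)cc(C)[nH]c2=O)c1F` in this assay gives > 150000 nM, which is a limit of the assay and not a number. Among the compounds with values here, this is the limit of > 150000 nM in this assay, at which 1 of the 2 values shown sits, so compound 1 stands as the sole quantified point and no measured step exists.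

Compound 3 `Cc1cc(C)c(CN2CCc3c(F)cc(O[C@@H]4CCOC4)c(Cl)c3C2=O)c(=O)[nH]1` has not yet been measured in this assay. It differs from compound 1 by fluoro in place of hydrogen on an aromatic carbon; in words, fluoro in place of hydrogen on an aromatic carbon. The change adds a single heavy atom, no ring, no donors, no acceptors and no charge.

Within the data shown here, with no measured step to lean on, the expectation rests on the small size of the change. Compound 3 is expected to give 25 nM, with a range from 8 nM to 80 nM. The step of a 1.1-fold lower number from compound 1 to compound 3 (0.05 log units; within the scatter) is therefore expected to stay within the usual scatter, with no direction claimed beyond it.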

Compound 3, half-maximal inhibitory concentration: 56 nM
The estimate for compound 3 lay 2.2-fold (0.35 log units) below the measured number, and the stated range covers the measured number.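

Going by these compounds alone, this is the first measured step, and in this assay it reads a 2.0-fold higher number from compound 1 to compound 3 (0.30 log units; within the scatter). On this single pair, the aromatic carbon ortho to a fused ring and para to a chloro group can carry fluoro in place of hydrogen without a difference that can be told from the scatter, so compound 1 and compound 3 cannot be put in order on this read-out. Within the data shown here, nothing measured here bears on how this substitution acts on the read-out, and the one pair gives no reason for the step.

The compounds shown leave open whether this position admits anything other than fluoro, such as a nitrile, an amine or a carboxylic acid, all of which differ from fluoro in their atoms and would test the position more widely than a single added fluorine. They also leave open whether the result for fluoro at this position holds when the (oxolan-3-yl)oxy group or the chloro group on the same ring is replaced, for example by an ethoxy group or a bromo group.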